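The source may hold more compounds than are shown below. What is called first, only, known or untested is meant among the compounds shown, and "the series" means these compounds.

Measured compounds:
compound 1 `O=C(CN(c1nc(Cl)nc2[nH]cnc12)C1CC1)NCC(=O)OCc1ccccc1` — 27.2%
compound 2 `O=C(CN(c1ncnc2c1ncn2C1CCCCO1)C1CC1)NCC(=O)OCc1ccccc1` — 25.9%
compound 3 `C[C@@H](O)[C@H](NC(=O)CN(c1nc(Cl)nc2[nH]cnc12)C1CC1)C(=O)OCc1ccccc1` — 29.9%

In a functional assay on the whole organism (Tail, strain ICR) with Mus musculus as the target, in the tail flick test, with a stated time of 90 min, at a dose of 25 umol/kg by the oral route (on this read-out higher numbers stand for a stronger effect at the one dose given and lower numbers for a weaker effect), compound 3 gives the highest of the three numbers, yet its gaps to compound 1 and to compound 2 are each within the scatter, so the three cannot be ordered. Among the compounds with values here, the only measured step at the same place is a number 2.7 percentage points higher from compound 1 to compound 3 (within the scatter), itself within the scatter. Compound 4 `NCCCC[C@H](NC(=O)CN(c1nc(Cl)nc2[nH]cnc12)C1CC1)C(=O)OCc1ccccc1` differs from compound 3 by 4-aminobutyl in place of 1-hydroxyethyl on a saturated chain carbon bound to an amide-type nitrogen and a carbonyl carbon. Within the data shown here, no measured step puts 4-aminobutyl at this place, so the bearing of that one step is loose; it shows only that changing the group on the saturated chain carbon has so far moved nothing beyond the scatter. The step expected here is a number 1.9 percentage points lower from compound 3 to compound 4 (within the scatter), none beyond the scatter. Compound 4 is therefore estimated at 28%, within 15% to 42%.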

Compound 4, a percentage reported as activity, at one dose (the size of the read-out at that dose, not a potency): 35.3%
For compound 4 the middle estimate is 7.3 percentage points below the measured one, within the range that was stated.
By their numbers in this assay, from the lowest: compounds 2, 1, 3 and 4 (each within the scatter of the next).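

With 4-aminobutyl on the saturated chain carbon bound to an amide-type nitrogen and a carbonyl carbon, this assay shows a number 5.4 percentage points higher from compound 3 to compound 4 (within the scatter) and a number 8.1 percentage points higher from compound 1 to compound 4 (within the scatter). This place has now carried hydrogen, 1-hydroxyethyl and 4-aminobutyl, a chain ending in an amine, without any step beyond the scatter. No supporting measurement bears on this result.

Going by these compounds, whether a carboxylic acid or a longer chain at this place would give a step beyond the scatter remains open. Also open, on these data alone, is whether 4-aminobutyl gives a similar reading on the core of compound 2.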